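Swapping the Methoxyphenyl End for Naphthalene

The source may report more compounds than this note shows. Statements on the series, on what has been measured and on what is new or still open speak of the compounds shown alone.

Compound 1 `COc1ccccc1/C=C/C(=O)/C=C/c1ccc(OCc2cn(CCCOc3cc(=O)oc4ccccc34)nn2)c(OC)c1` gives 53% in a functional assay on HCT-116 cells (Homo sapiens) for inhibition, read by sulforhodamine B assay, with a stated time of 48 h, tested at 50 uM; a higher number here means more inhibition of growth at the concentration tested, a lower number less inhibition of growth. For the measured compounds named here, this is the lowest of the two numbers known; the other comes from compound 2 `COc1ccc(/C=C/C(=O)/C=C/c2ccc(OCc3cn(CCOc4cc(=O)oc5ccccc45)nn3)c(OC)c2)cc1OC`, which gives 82% in this assay, a gap beyond the scatter, though compound 2 differs from compound 1 in more than one place, so no single step connects them. Compound 3 `COc1cc(/C=C/C(=O)/C=C/c2cccc3ccccc23)ccc1OCc1cn(CCCOc2cc(=O)oc3ccccc23)nn1` differs from compound 1 in one place: naphthalen-1-yl in place of 2-methoxyphenyl on a double-bonded chain carbon bound to a double-bonded chain carbon. Going by the values given here, no measured step of this kind exists, so only a small change, not beyond the scatter, is expected, a number 2 percentage points higher from compound 1 to compound 3 (within the scatter). Compound 3 is expected to give 55% in this assay, within 30% to 80%.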

Compound 3, percent growth inhibition at one concentration: 66%
For compound 3 the middle estimate is 11 percentage points below the measured one, within the range that was stated.
By their numbers in this assay, from the lowest: compound 1; then compound 3; then compound 2.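

For the compounds shown here, on a double-bonded chain carbon bound to a double-bonded chain carbon, the change to naphthalen-1-yl gives a number 13 percentage points higher from compound 1 to compound 3 (beyond the scatter) in this assay and is the first single-place step in the set. It shows that this position affects growth inhibition and that the oxygen of 2-methoxyphenyl is not needed to hold the level of compound 1. Nothing at hand explains the rise.

The compounds shown do not separate the effect of the second ring from the loss of the methoxy group. On these data alone, a plain phenyl group or a dimethylamino group at this place remains untested here.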